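Adding a nitro group to compound 2

This account rests on a few compounds, and the source may have more. Where it says the series, first, only, none or still open, it means among the compounds named here.

Compound 1 `CCOC(=O)c1cccnc1S(=O)(=O)NC(=O)Nc1ccc(Cl)cc1`: 14000 nM
Compound 2 `CCOC(=O)c1cccnc1SNC(=O)Nc1ncccn1`: 1000 nM

Both values come from a functional assay on K562 cells (Homo sapiens) for cytotoxicity; on this read-out higher numbers stand for weaker inhibition and lower numbers for stronger inhibition. Of the two, compound 2 has the lower number, 1000 nM, and therefore the stronger inhibition, while compound 1 stands at 14000 nM. That gap lies well beyond the usual scatter of repeated measurements. The two compounds differ in more than one place, and no single change can be credited with the gap.

Compound 3 `CCOC(=O)c1cc([N+](=O)[O-])cnc1SNC(=O)Nc1ncccn1` keeps the structure of compound 2 except at one spot: nitro in place of hydrogen on an aromatic carbon, two atoms from the ring nitrogen (nitro in place of hydrogen on an aromatic carbon). Among the compounds with values here, no pair of measured compounds differs in just one place, so the data offer no direct guide to a change like this. With compound 2 at 1000 nM as the only close reference, the expectation is no shift beyond the scatter in this assay, with real uncertainty in either direction. The estimated change is a 1.3-fold lower number from compound 2 to compound 3 (0.10 log units; within the scatter). For compound 3 the estimated value is 800 nM, with an expected range from 200 nM to 3500 nM.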

Compound 3, half-maximal inhibitory concentration: 200 nM
For compound 3 the middle estimate is 4.0-fold (0.60 log units) above the measured one, and the stated range covers the measured number.
By their numbers in this assay, from the lowest: compound 3; then compound 2; then compound 1.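

Replacing hydrogen with nitro on the aromatic carbon two atoms from the ring nitrogen gives, in this assay, a 5.0-fold lower number from compound 2 to compound 3 (0.70 log units; beyond the scatter). Within the data shown here, compound 2 and compound 3 differ in this one place only, so this is the first change in the set whose effect can be read on its own, and it shows that this carbon, para to a large group and meta to the ethoxycarbonyl group, is a position where a substituent can clearly shift the number, here towards stronger inhibition. No measurement given here bears on why the nitro group has this effect.

A single group on a single carbon cannot show whether the step belongs to nitro in particular or would also appear with another group there, such as an amine, a nitrile, a chlorine atom or a methyl group. It also leaves open whether the same step would appear with nitro on another carbon of this ring, or with the ethyl ester replaced by a carboxylic acid.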